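The compounds below may be only part of what the source reports. "The series", "measured", "known", "first", "only" and "open" are said of these compounds alone.

Four compounds are built on a shared core bearing the same side chain. Compound 1 `ClCc1ccccc1Cn1cnc2c(Cl)nc(Cl)nc21` and compound 2 `ClCc1ccccc1Cn1cnc2c(Cl)ncnc21` differ only by chloro in place of hydrogen on an aromatic carbon. In a functional assay on OVCAR-8 cells (Homo sapiens) for cytotoxicity, read by sulforhodamine B assay, with a stated time of 48 h (on this read-out lower numbers stand for stronger inhibition of growth and higher numbers for weaker inhibition of growth), compound 2 gives 5240 nM, and compound 1 gives 2810 nM, so the change made a 1.9-fold lower number from compound 2 to compound 1 (0.27 log units; within the scatter). Compound 3 `ClCc1ccccc1Cn1cnc2ncnc(Cl)c21` has the same atoms as compound 2 joined differently; the difference between the two cores is not broken down here. In this assay compound 3 gives 8700 nM. Compound 4 `ClCc1ccccc1Cn1cnc2nc(Cl)nc(Cl)c21` is still unmeasured; it differs from compound 3 by chloro in place of hydrogen on an aromatic carbon, the same change at the same place as that between compound 2 and compound 1. Resting on a 1.9-fold lower number from compound 2 to compound 1 (0.27 log units; within the scatter), the expected step is a 1.7-fold lower number from compound 3 to compound 4 (0.24 log units; within the scatter). Compound 4 is therefore estimated to give 5000 nM, somewhere from 2500 nM to 10000 nM.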

Compound 4, concentration for total growth inhibition: 7070 nM
Compound 4: the middle estimate sits 1.4-fold (0.15 log units) below what was measured; the measured number falls inside the stated range.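

Putting chloro in place of hydrogen on the core of compound 3 gives, in this assay, a 1.2-fold lower number from compound 3 to compound 4 (0.09 log units; within the scatter). Set beside the earlier case, the two steps agree: the same change on two cores in this assay, a 1.9-fold lower number (0.27 log units; within the scatter) from compound 2 to compound 1 and a 1.2-fold lower number (0.09 log units; within the scatter) from compound 3 to compound 4, 1.5-fold (0.18 log units) apart, within the scatter of two such steps. So the change carries across these two cores without a difference that can be told from the scatter, but each step also lies within the scatter, so neither shows that the chloro group really alters growth inhibition, and two cores do not make a rule for the series.

The compounds shown leave open whether another group on this carbon between two ring nitrogen atoms, such as an amine, would give a step beyond the scatter on either core.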